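This account rests on a few compounds, and the source may have more. Where it says the series, first, only, none or still open, it means among the compounds named here.

Compound 1, `Cc1ccc(S(=O)(=O)NC(=O)Nc2ccc(Cl)c(Cl)c2)s1`: 61%
Compound 2, `COc1ccc(S(=O)(=O)NC(=O)Nc2ccc(Cl)cc2)s1`: 100%
Compound 3, `CSc1ccc(S(=O)(=O)NC(=O)Nc2ccc(Cl)cc2)s1`: 62%

Of the compounds shown here, three sharing one core have been measured in a functional assay on the whole organism (6C3HED cells, Mus musculus) for inhibition, at a dose of 300 mg/kg by the oral route; on this read-out higher numbers stand for more inhibition at the one dose given (going by the name of the read-out) and lower numbers for less inhibition. Compound 3 stands second highest of the three; its value and that of compound 1 lie within the scatter of each other, while compound 2 stands beyond the scatter above it. For the measured compounds named here, the one step measured at the position in question is a number 38 percentage points lower from compound 2 to compound 3 (beyond the scatter), a large fall.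

Compound 4, `CC(C)c1ccc(S(=O)(=O)NC(=O)Nc2ccc(Cl)cc2)s1`, differs from compound 3 in one place: isopropyl in place of methylsulfanyl on an aromatic carbon. Going by the values given here, no measured step covers this exchange; the step from compound 2 to compound 3 shows only that a change of group at this ring carbon can move the read-out strongly, not in which direction an isopropyl would move it. Compound 3 is therefore taken as the anchor, and the step from compound 3 to compound 4 is expected to be a number 2 percentage points lower from compound 3 to compound 4 (within the scatter), with a wide band to allow for a movement of either sign. Compound 4 is estimated at 60%, between 25% and 95%.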

Compound 4, a percentage reported as inhibition, in the whole organism at one dose (the size of the read-out at that dose, not a potency): 63%
For compound 4 the middle estimate is 3 percentage points below the measured one; low and high end bracket the measured number.
By their numbers in this assay, from the lowest: compounds 1, 3 and 4 (each within the scatter of the next); then compound 2.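

In this assay, exchanging methylsulfanyl for isopropyl at this ring carbon gives a number 1 percentage points higher from compound 3 to compound 4 (within the scatter), so these two groups cannot be told apart on this read-out. The exchange of methoxy for isopropyl gives a number 37 percentage points lower from compound 2 to compound 4 (beyond the scatter), which shows that a large fall from the methoxy compound also occurs with a group that carries no sulfur and no hydrogen-bond acceptor. Of the three groups compared here at this carbon, methoxy alone stands apart, and nothing available explains why.

The compounds shown leave open whether an ethoxy group, a longer ether chain or an amine at this ring carbon would stay at the level of compound 2 or fall to that of compounds 3 and 4. They also leave open whether a single oxygen-linked group is enough to give the higher read-out.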